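The source may hold more compounds than are shown below. What is called first, only, known or untested is meant among the compounds shown, and "the series" means these compounds.

Values in a physicochemical assay for acid dissociation, so far:

- compound 1 `Cc1nc2c(/C=C/Cc3ccccc3)cccn2c1N` gives 6.75
- compound 2 `OCc1c(C(F)(F)F)nc2c(OCc3ccccc3)cccn12` gives 2
- compound 3 `Cc1nc2c(/C=C/c3ccccc3)cccn2c1C` gives 7.2

Compound 3 at 7.2 holds the highest of the three numbers, beyond the scatter from compound 1 and further still from compound 2. The next compound, compound 4 `Cc1nc2c(/C=C\c3ccccc3)cccn2c1C`, is still unmeasured. The change is the two compounds have the same atoms and bonds and differ only in configuration as drawn: 1 of 1 stereo elements differ; a double bond is drawn E in compound 3 and Z in compound 4 and nothing else: a double bond is drawn E in compound 3 and Z in compound 4. Within the data shown here, no measured pair differs in one place, so this expectation has no direct precedent. In this assay the expected result is no step beyond the scatter, with a number 0.20 log units lower from compound 3 to compound 4 (within the scatter) as the estimated step. The estimate for compound 4 is 7 with 6.6 to 7.4 as its expected range.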

Compound 4, acid dissociation constant: 7.2
For compound 4 the middle estimate is 0.20 log units below the measured one; low and high end bracket the measured number.
By their numbers in this assay, from the lowest: compound 2; then compound 1; then compounds 3 and 4 (each within the scatter of the next).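

In this assay, redrawing the double bond from E to Z gives no change at the digits printed from compound 3 to compound 4 (within the scatter). Among these compounds, this is the first pair that differs in one place, so the configuration of this double bond can now be read directly: the fact that compounds 3 and 4 differ only in the configuration as drawn In this pair, the double bond can be drawn either way without a step beyond the scatter.

Going by these compounds, it remains open whether E and Z stay level in this assay once the arm bearing the double bond carries a carboxylic acid. An amide in place of the double bond is also untested among the compounds shown.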